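This account rests on a few compounds, and the source may have more. Where it says the series, first, only, none or still open, it means among the compounds named here.

For the measured compounds named here, in a functional assay on MDA-MB-231 cells (Homo sapiens) for inhibition, read by MTT assay, with a stated time of 72 h (on this read-out higher numbers stand for weaker inhibition and lower numbers for stronger inhibition), compound 1 `Nc1nc2cc(-c3nn(CCCC(=O)NO)c4ncnc(N)c34)ccc2o1` gives 19500 nM, the only exact number among the measured compounds. Compound 2 `Nc1ncnc2c1c(-c1cnc3[nH]ccc3c1)nn2CCCCC(=O)NO` reads > 50000 nM, which is a limit of the assay. Compound 3 `Nc1ncnc2c1c(-c1cnc3[nH]ccc3c1)nn2CCC(=O)NO` reads > 150000 nM, which is also a limit.

The unmeasured compound 4 `CNC(=O)CCCCCCCn1nc(-c2ccc3oc(N)nc3c2)c2c(N)ncnc21` differs from compound 1 as follows: 4-(methylcarbamoyl)butyl in place of hydroxycarbamoyl on a saturated chain carbon, three bonds along the chain from an aromatic nitrogen. In words, 4-(methylcarbamoyl)butyl stands in place of hydroxycarbamoyl on a saturated chain carbon, three bonds along the chain from an aromatic nitrogen.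

Going by the values given here, only one measured step is available, a step that the two limits leave unreadable from compound 2 to compound 3. Its size cannot be read, and hydroxycarbamoyl is still present at its end, so it gives no measure of this exchange. The expectation therefore stays anchored on compound 1 at 19500 nM, with a wide margin and a tentative lean towards weaker inhibition in this assay. The expected change is a 1.3-fold higher number from compound 1 to compound 4 (0.11 log units; within the scatter). For compound 4 the estimated value is 25000 nM, with an expected range of 6000 nM to 100000 nM.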

Compound 4, half-maximal inhibitory concentration: 2900 nM
Estimate against measurement, compound 4: 8.6-fold (0.94 log units) above; the measured number lies below the stated range.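

In this assay, the exchange gives a 6.7-fold lower number from compound 1 to compound 4 (0.83 log units; beyond the scatter), which shows that inhibition in this assay does not depend on keeping hydroxycarbamoyl at this place, on a saturated chain carbon, three bonds along the chain from an aromatic nitrogen. The earlier compounds shown here all carry hydroxycarbamoyl, and the step between them cannot be read, so they offered no measured view of what happens when that group leaves. No measurement shown gives a cause for this step.

The exchange alters the end group and the chain length together, and the compounds shown do not separate the two: it remains open how methylcarbamoyl would read on the shorter chain, or hydroxycarbamoyl on the longer one. As far as these compounds go, how a carboxylic acid or an amine at the end of the chain would read also remains open.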